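This account rests on a few compounds, and the source may have more. Where it says the series, first, only, none or still open, it means among the compounds named here.

Compound 1 `COC(=O)c1ccc(C(=O)Nc2cccc3c2N(S(=O)(=O)c2ccc(OC)cc2)CC3)cc1` and compound 2 `COc1ccc(S(=O)(=O)N2CCc3cccc(NC(=O)c4ccc(F)cc4)c32)cc1` share one core and differ in a single group on an aromatic carbon. Among the compounds with values here, in a functional assay on KB cells (Homo sapiens) for cytotoxicity (a higher number here means a weaker inhibitor, a lower number a stronger inhibitor), compound 1 gives 376 nM, which is the highest of the two numbers measured so far. In this assay compound 2 gives 93 nM. Within the data shown here, the one measured step, a 4.0-fold lower number from compound 1 to compound 2 (0.61 log units; beyond the scatter), shows that replacing methoxycarbonyl with fluoro is worth a modest gain.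

Compound 3 `COc1ccc(C(=O)Nc2cccc3c2N(S(=O)(=O)c2ccc(OC)cc2)CC3)cc1` has not yet been measured. It differs from compound 1 in one place: methoxy in place of methoxycarbonyl on an aromatic carbon. This change resembles the step from compound 1 to compound 2 in that methoxycarbonyl leaves in both, but here methoxy enters rather than fluoro, so that step is only a partial guide. Taking it as the best available pointer, a modest fall in the number is expected, though a smaller change is also plausible. Compound 3 is therefore expected to give 160 nM, with a range from 50 nM to 500 nM. That estimate corresponds to an expected step of a 2.4-fold lower number from compound 1 to compound 3 (0.37 log units; beyond the scatter).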

Compound 3, half-maximal inhibitory concentration: 2600 nM
Estimate against measurement, compound 3: 16-fold (1.21 log units) below; the measured number lies above the stated range.
By their numbers in this assay, from the lowest: compound 2; then compound 1; then compound 3.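

This result shows that losing methoxycarbonyl from this aromatic carbon, para to a large group, does not by itself lower the number in this assay: the change to methoxy gives a 6.9-fold higher number from compound 1 to compound 3 (0.84 log units; beyond the scatter), opposite in direction to the change to fluoro. The direct comparison of the two smaller replacements gives a 28-fold higher number from compound 2 to compound 3 (1.45 log units; beyond the scatter), so the outcome depends strongly on which group enters, and the order does not follow the heavy-atom count, since methoxy has fewer heavy atoms than methoxycarbonyl yet compound 3 gives the higher number. No measurement available here explains why these groups differ.

Going by these compounds, three groups at one position give only three points, so it remains open where other groups, such as chloro, hydroxyl, an amine or a carboxylic acid, would fall relative to fluoro and methoxy. On these data alone, it also remains open whether the same order would hold if the 4-methoxyphenyl sulfonyl part of the shared core were changed, as every compound here carries that part unchanged.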